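The source may hold more compounds than are shown below. What is called first, only, known or untested is meant among the compounds shown, and "the series" means these compounds.

Working notes on the series. In a functional assay, read by spectrophotometry, with a stated time of 1 h (a lower number here means a stronger inhibitor, a higher number a weaker inhibitor), compound 1 `O=c1[nH]c2ccccc2cc1/C=N/CCO` gives 3310000 nM. In this assay compound 2 `Cc1ccc2[nH]c(=O)c(/C=N/CCO)cc2c1` gives 4180000 nM, and compound 3 `Cc1ccc2[nH]c(=O)c(/C=N/Cc3ccccc3)cc2c1` gives 6920000 nM. The cores of compound 2 and compound 3 differ by phenyl in place of hydroxymethyl on a saturated chain carbon bound to a double-bonded nitrogen, a change that gave a 1.7-fold higher number from compound 2 to compound 3 (0.22 log units; within the scatter). Within one core, hydrogen in place of methyl on an aromatic carbon gave a 1.3-fold lower number from compound 2 to compound 1 (0.10 log units; within the scatter), so neither change moved the number beyond the usual scatter.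

Compound 4 `O=c1[nH]c2ccccc2cc1/C=N/Cc1ccccc1` has not yet been measured in this assay. It differs from compound 3 by hydrogen in place of methyl on an aromatic carbon, the same change as that made from compound 2 to compound 1; among the compounds here this change occurs two times. For the measured compounds named here, a step of similar size is expected from compound 3 to compound 4 in this assay, a 1.3-fold lower number from compound 3 to compound 4 (0.12 log units; within the scatter), which rests on the single measured pair because the step of a 1.3-fold lower number from compound 2 to compound 1 (0.10 log units; within the scatter) stayed within the scatter. Compound 4 is estimated at 5300000 nM, with a range from 2500000 nM to 12000000 nM, pending the measurement.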

Compound 4, half-maximal inhibitory concentration: 3140000 nM
For compound 4 the middle estimate is 1.7-fold (0.23 log units) above the measured one, and the stated range covers the measured number.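

Hydrogen in place of methyl on an aromatic carbon gave a 2.2-fold lower number from compound 3 to compound 4 (0.34 log units; beyond the scatter), and this step does not differ from the earlier one on the other core: the same change on two cores in this assay, a 1.3-fold lower number (0.10 log units; within the scatter) from compound 2 to compound 1 and a 2.2-fold lower number (0.34 log units; beyond the scatter) from compound 3 to compound 4, 1.7-fold (0.24 log units) apart, within the scatter of two such steps

Phenyl in place of hydroxymethyl on a saturated chain carbon bound to a double-bonded nitrogen gave a 1.1-fold lower number from compound 1 to compound 4 (0.02 log units; within the scatter), and this change likewise carries from one core to the other without a difference: the same change on two cores in this assay, a 1.7-fold higher number (0.22 log units; within the scatter) from compound 2 to compound 3 and a 1.1-fold lower number (0.02 log units; within the scatter) from compound 1 to compound 4, 1.7-fold (0.24 log units) apart, within the scatter of two such steps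

This agreement rests on the same four compounds in this assay and on one pair of steps per change, so it shows no conflict between the cores but does not prove that either change is independent of the core in general, nor that the methyl step is truly larger on one core than on the other.

As far as these compounds go, the aromatic carbon carries only hydrogen or methyl here, so a chlorine atom or a methoxy group at that place remains open. The chain carries only hydroxymethyl or phenyl, which leaves open how an amine, a carboxylic acid or a longer chain would behave.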